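From Propanoylamino to Methoxy: What Cytotoxicity to Expect

The source may report more compounds than this note shows. Statements on the series, on what has been measured and on what is new or still open speak of the compounds shown alone.

Of the compounds shown here, three have been measured in an ADME assay on MDBK cells (Bos taurus) for cytotoxicity, read by MTT assay, with a stated time of 96 h; on this read-out higher numbers stand for lower toxicity in this test and lower numbers for higher toxicity in this test. Compound 1 `Fc1ccc(-c2nc3cc(C(F)(F)F)ccc3[nH]2)cc1` carries a fluoro group and gives 19000 nM. Compound 2 `CCC(=O)Nc1ccc(-c2nc3ccccc3[nH]2)cc1` carries a propanoylamino group without a trifluoromethyl group; in this assay compound 2 reaches only the limit > 100000 nM, which is a ceiling of the assay and not a number. Compound 3 `CCC(=O)Nc1ccc(-c2nc3cc(C(F)(F)F)ccc3[nH]2)cc1` joins the propanoylamino group with the trifluoromethyl group of compound 1; in this assay compound 3 likewise stops at the limit > 100000 nM, again a ceiling rather than a number. Compound 3 thus stands at the top of the numbers shown, together with compound 2, because both sit at the limit of > 100000 nM in this assay, at which 2 of the 3 values shown sit. For the measured compounds named here, the one readable step among them is an at least 5.2-fold higher number from compound 1 to compound 3 (0.72 log units; beyond the scatter). The step that the two limits leave unreadable from compound 2 to compound 3 cannot be sized.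

Compound 4 `COc1ccc(-c2nc3cc(C(F)(F)F)ccc3[nH]2)cc1` differs from compound 3 as follows: methoxy in place of propanoylamino on an aromatic carbon. The measured step that bears on this change is an at least 5.2-fold higher number from compound 1 to compound 3 (0.72 log units; beyond the scatter), which shows that a fluoro group at this place gave a lower number than propanoylamino. Methoxy is neither of these, so a number between those of compound 1 and compound 3 seems most likely. Compound 4 is therefore expected to give about 40000 nM in this assay, within a range from 12000 nM to 100000 nM. The expected step is an at least 2.5-fold lower number from compound 3 to compound 4 (0.39 log units; beyond the scatter), a move back toward the number of compound 1.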

Compound 4, half-maximal cytotoxic concentration: > 100000 nM
Compound 4: no number, only a limit; the forecaster's own chance of this, stated with the estimate: 30%; middle value at least 2.5-fold (0.39 log units) away from the limit.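

The change from fluoro to methoxy gives an at least 5.2-fold higher number from compound 1 to compound 4 (0.72 log units; beyond the scatter), so in this assay the number of compound 1 is not matched by this second replacement on the aromatic carbon para to a large group. Methoxy has 2 heavy atoms and no hydrogen-bond donor, against 5 heavy atoms and 1 donor for propanoylamino, so with trifluoromethyl on the shared core, neither the longer chain nor the amide hydrogen is needed to move clear of compound 1. Compound 4 gives only a limit of the assay and not a number, and the steps among the compounds at that limit cannot be read, which leaves any order between methoxy and propanoylamino hidden: the limit of > 100000 nM in this assay, at which 3 of the 4 values shown sit.

The compounds shown leave open whether fluoro is unusual at this place or whether a small group such as chloro, or an amine or a carboxylic acid, would also give a lower number. They also leave open how far below the limit any of these compounds might fall at higher concentrations, and a hydroxy group at this place would test whether the methyl of methoxy matters.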